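Removing the Core Methyl of a Leukotriene Receptor Antagonist

The compounds below may be only part of what the source reports. "The series", "measured", "known", "first", "only" and "open" are said of these compounds alone.

Compound 1, `Cc1c(F)cccc1CCCCOc1ccc(/C=C/c2cccc3c(CCCC(=O)O)c(C)n(CC(=O)O)c23)cc1`, gives 7.2 nM in a functional assay on HEK293 cells for antagonist activity at cysteinyl leukotriene receptor 2 (Homo sapiens), read by fluorescence and calcium flux, with stated times of 30 min and 1 h; a lower number here means a stronger inhibitor, a higher number a weaker inhibitor.
Compound 2, `Cc1c(CCCC(=O)O)c2cccc(/C=C/c3ccc(OCCCCc4cc(F)c(F)c(F)c4F)cc3)c2n1CC(=O)O`, gives 1.5 nM in this assay.

Going by the values given here, compound 1 has the higher of the two numbers measured so far, which means it is the weaker of the two inhibitors. Among the compounds with values here, its nearest neighbour is compound 2, and the one measured step, a 4.8-fold lower number from compound 1 to compound 2 (0.68 log units; beyond the scatter), changes only the aryl group at the far end of the chain.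

Compound 3, `Cc1c(F)cccc1CCCCOc1ccc(/C=C/c2cccc3c(CCCC(=O)O)cn(CC(=O)O)c23)cc1`, has not been measured. It differs from compound 1 at the shared core: hydrogen in place of methyl on an aromatic carbon. Within the data shown here, no measured step touches this part of the molecule, so nothing among the known values speaks directly for or against the change. Without any bearing step, the expectation is that the number stays within the scatter, with a modest loss the likelier lean if anything shifts, giving an estimated step of a 1.5-fold higher number from compound 1 to compound 3 (0.18 log units; within the scatter). Compound 3 is therefore expected to give about 11 nM in this assay, in a range from 4 nM to 35 nM.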

Compound 3, half-maximal inhibitory concentration: 14 nM
For compound 3 the middle estimate is 1.3-fold (0.10 log units) below the measured one, and the stated range covers the measured number.
By their numbers in this assay, from the lowest: compound 2; then compounds 1 and 3 (each within the scatter of the next).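

Within the shared core, hydrogen in place of methyl on this aromatic carbon, next to the ring nitrogen, gives in this assay a 1.9-fold higher number from compound 1 to compound 3 (0.29 log units; within the scatter), so compounds 1 and 3 cannot be told apart here. This methyl, a single carbon, therefore shows no measurable contribution in this pair. Going by these compounds alone, the earlier step changed only the aryl group at the far end of the chain, so this is the first measured look at a change to the core itself, and nothing available explains the result.

Still open, from the compounds shown here alone, is how an ethyl group or a chlorine atom on this carbon would fare, since only methyl and hydrogen appear here. Going by these compounds, it is also open whether the same swap would give a similar result with the 2,3,4,5-tetrafluorophenyl group of compound 2 at the end of the chain.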